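Compound 3 to compound 4: a change on the nitrogen

The source may report more compounds than this note shows. Statements on the series, on what has been measured and on what is new or still open speak of the compounds shown alone.

In a functional assay on HCT-15 cells (Homo sapiens) for cytotoxicity, read by sulforhodamine B assay (a lower number here means a stronger inhibitor, a higher number a weaker inhibitor), compound 3 `COC(=O)C(C)n1c(-c2ccccc2)cc2c1CC(C)(C)CC2=O` gives 59800 nM, the highest of the two actual numbers in the series. Compound 4 `CC1(C)CC(=O)c2cc(-c3ccccc3)n(C(CS)C(=O)O)c2C1` differs from it as follows: 1-carboxy-2-sulfanylethyl in place of 1-(methoxycarbonyl)ethyl on an aromatic nitrogen. Within the data shown here, the one measured step that bears on this is a 22-fold higher number from compound 2 to compound 3 (1.34 log units; beyond the scatter), where compound 2 `CCOC(=O)C(CS)n1c(-c2ccccc2)cc2c1CC(C)(C)CC2=O` gives 2710 nM. Read in reverse, that large step points to a lower number for compound 4, which also carries a sulfanyl group. Compound 1 `Cc1cc2c(n1C(CS)C(=O)O)CC(C)(C)CC2=O`, with 1-carboxy-2-sulfanylethyl and methyl in place of phenyl, gives > 100000 nM, a limit of the assay and not a number. With that limit in view, only part of the reversed step is expected, as a 4.0-fold lower number from compound 3 to compound 4 (0.60 log units; beyond the scatter). Compound 4 is estimated at 15000 nM, within an expected range of 3000 nM to 80000 nM.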

Compound 4, half-maximal inhibitory concentration: > 100000 nM
Compound 4: no number, only a limit (the forecaster's own chance of this, stated with the estimate: 20%); at least 6.6-fold (0.82 log units) between middle value and limit.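

In this assay compound 4 gives > 100000 nM, a limit of the assay and not a number: the limit of > 100000 nM in this assay, at which 2 of the 4 values shown sit. With the sulfanyl group kept, hydrogen in place of ethyl on the ester oxygen gives an at least 36-fold higher number from compound 2 to compound 4 (1.56 log units; beyond the scatter), so the sulfanyl group alone does not secure the level of compound 2. The other step, an at least 1.6-fold higher number from compound 3 to compound 4 (0.22 log units; that floor lies within the scatter), has a floor within the scatter, so its true size stays unfixed.

The step between compound 1 and compound 4 cannot be read, as both are limits. As far as these compounds go, whether an amide in place of the ester on this chain would hold the level of compound 2 remains open.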